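The source may report more compounds than this note shows. Statements on the series, on what has been measured and on what is new or still open speak of the compounds shown alone.

Measured compounds in a functional assay on PC-9 cells (Homo sapiens) for inhibition, read by MTT assay, with a stated time of 72 h; on this read-out higher numbers stand for weaker inhibition and lower numbers for stronger inhibition:
- compound 1 `Cc1cc(Nc2cc(-c3ccccc3)[nH]n2)n2nc(SCc3nc4ccccc4[nH]3)nc2n1`: 4840 nM
- compound 2 `Cc1cc(Nc2cc(-c3ccc(F)cc3)[nH]n2)n2nc(SCc3ccc(Br)cc3)nc2n1`: 6210 nM
- compound 3 `Cc1cc(Nc2ccn(Cc3ccc(C(F)(F)F)cc3)n2)n2nc(SCc3ccc(Br)cc3)nc2n1`: 5580 nM

Compound 1 gives 4840 nM in this assay, a number that sits alongside those of compound 2 and compound 3; the gaps to both fall within the usual scatter, so nothing separates the three here. No pair of these compounds differs in a single place, and no measured step is available to lean on.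

Compound 4 `Cc1cc(Nc2cc(-c3ccccc3)[nH]n2)n2nc(SCC3CCCCC3)nc2n1` is not yet measured. It follows from compound 1 by this change: cyclohexyl in place of 1H-benzimidazol-2-yl on a saturated chain carbon bound to a sulfur.

Going by the values given here, with no comparable step among the measured compounds, the expected move in this assay is small and on the weaker side, mostly inside the scatter. The step expected is a 1.4-fold higher number from compound 1 to compound 4 (0.16 log units; within the scatter). Compound 4 is expected to give 7000 nM, with a range from 2500 nM to 20000 nM.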

Compound 4, half-maximal inhibitory concentration: > 50000 nM
Compound 4 was reported as a limit; the forecaster's own chance of this, stated with the estimate: 20%; middle value at least 7.1-fold (0.85 log units) from the limit.
By their numbers in this assay, from the lowest: compounds 1, 3 and 2 (each within the scatter of the next). At a limit, above all of these: compound 4.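

In this assay, this place on the saturated chain carbon bound to a sulfur proves sensitive: cyclohexyl in place of 1H-benzimidazol-2-yl gives an at least 10-fold higher number from compound 1 to compound 4 (1.01 log units; beyond the scatter). Compound 4 stands as a limit and not a number, so the step has no upper bound: the limit of > 50000 nM in this assay, at which 1 of the 4 values shown sits. The earlier compounds shown here, all within the scatter of one another and linked by no single-place step, gave no sign of this.

The compounds shown do not separate the aromatic rings of 1H-benzimidazol-2-yl from its hydrogen-bond donor and acceptor as the part that counts. Going by these compounds, how a pyridine or a piperidine would read at this place remains open.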